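Working notes on a short amide series

The compounds below may be only part of what the source reports. "The series", "measured", "known", "first", "only" and "open" are said of these compounds alone.

Measured so far in an ADME assay on Raji cells (Homo sapiens) for inhibition, with a stated time of 72 h; on this read-out higher numbers stand for an effect only at larger amounts of compound and lower numbers for an effect already at smaller amounts:
- compound 1 `O=C(Nc1cccc(-c2nc3ccccc3s2)c1)c1cnccc1Cl`: 12000 nM
- compound 2 `O=C(Nc1cccc(-c2nc3ccccc3s2)c1)c1cnc(Cl)s1`: only a limit of the assay, > 25000 nM
- compound 3 `Cc1ccc(-c2nc3ccccc3s2)cc1NC(=O)c1cnccc1Cl`: only a limit of the assay, > 25000 nM

Compound 3 therefore stands at the limit of > 25000 nM in this assay, at which 2 of the 3 values shown sit, with no number of its own. The two measured steps both lead away from compound 1: an at least 2.0-fold higher number from compound 1 to compound 2 (0.31 log units; beyond the scatter), and an at least 2.0-fold higher number from compound 1 to compound 3 (0.31 log units; beyond the scatter). Only the second concerns the position now varied.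

Compound 4 `COc1ccc(-c2nc3ccccc3s2)cc1NC(=O)c1cnccc1Cl` differs from compound 3 by methoxy in place of methyl on an aromatic carbon. No measured step swaps methoxy for methyl, so nothing shown sets a direction for it; the expected change a step that the limit leaves unreadable from compound 3 to compound 4 is none beyond the scatter. Compound 4 is estimated at 30000 nM in this assay, between 10000 nM and 100000 nM, most likely again reported only as a limit.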

Compound 4, half-maximal effective concentration: 13000 nM
Beside the measured number, compound 4's estimate is 2.3-fold (0.36 log units) above it, and the stated range covers the measured number.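

Unlike methyl in compound 3, methoxy at this position, ortho to a large group, gives a number of its own in this assay, so a group here need not end at the limit. Against hydrogen, the step is a 1.1-fold higher number from compound 1 to compound 4 (0.03 log units; within the scatter), which leaves compound 4 not separated from compound 1. Against methyl, the step is an at least 1.9-fold lower number from compound 3 to compound 4 (0.28 log units; that floor lies within the scatter), so no preference for methoxy over methyl is established, and compound 3 remains only a limit: the limit of > 25000 nM in this assay, at which 2 of the 4 values shown sit.

On these data alone, whether an amine or a longer chain at this position also gives a measured number stays open. So does whether methoxy gives one alongside the 2-chloro-1,3-thiazol-5-yl group of compound 2.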